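This account rests on a few compounds, and the source may have more. Where it says the series, first, only, none or still open, it means among the compounds named here.

Measured compounds:
compound 1, `Cc1nn(Cc2ccccc2)c(C)c1NC(=O)c1ccc(COc2ccccc2)cc1`, 10000 nM
compound 2, `CNC(=O)c1cccc(Cn2nc(C)c(NC(=O)c3ccc(COc4ccccc4OC)cc3)c2C)c1`, 8500 nM

In a functional assay on MIA PaCa-2 cells (Homo sapiens) for antiproliferative activity, read by MTT assay, with a stated time of 72 h (on this read-out higher numbers stand for an effect only at larger amounts of compound and lower numbers for an effect already at smaller amounts), compound 1 gives 10000 nM and compound 2 gives 8500 nM. Compound 2 carries the lowest of the two numbers, but its nearest neighbour, compound 1, lies within the scatter of it, so no order between them can be read. Compound 1 and compound 2 differ in more than one place; their two values show only that both act in the same region of concentration.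

Compound 3 `CNC(=O)c1cccc(Cn2nc(C)c(NC(=O)c3ccc(COc4ccc(C(F)(F)F)cc4)cc3)c2C)c1` is not yet measured. It is compound 2 with 4-(trifluoromethyl)phenyl in place of 2-methoxyphenyl on an oxygen on a saturated carbon. Within the data shown here, no step of this kind is recorded among the measured compounds, so there is no basis for expecting a move beyond the scatter in this assay in either direction; the expected step for compound 3 is a 1.2-fold lower number from compound 2 to compound 3 (0.08 log units; within the scatter). Compound 3 is therefore estimated at 7000 nM, with a range from 2500 nM to 20000 nM.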

Compound 3, half-maximal effective concentration: 800 nM
The estimate for compound 3 lay 8.8-fold (0.94 log units) above the measured number, and the stated range ends above it.
By their numbers in this assay, from the lowest: compound 3; then compounds 2 and 1 (each within the scatter of the next).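

In this assay, the group on the oxygen on a saturated carbon proves to be a place where one change moves the number beyond the scatter: 4-(trifluoromethyl)phenyl in place of 2-methoxyphenyl gives an 11-fold lower number from compound 2 to compound 3 (1.03 log units; beyond the scatter). Compound 1 and compound 2 differ in more than one place, so their values could not show this; here the rest of compound 2 stays unchanged. Nothing at hand bears on the cause of this step.

From the compounds shown here alone, the change replaces both the substituent and its ring position, so it remains open whether the step follows the trifluoromethyl group, the loss of the methoxy group, or the new position. Going by these compounds, how 4-methoxyphenyl, 2-(trifluoromethyl)phenyl, or a phenyl ring bearing an amine or a carboxylic acid would read at this place also remains open.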